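A few compounds are considered here, and "the series" means these few. Any claim that something is new, unique, unknown or untested is made for them only; others in the source may bear on it.

Measured so far in an ADME assay on BaF3 cells (Mus musculus) for antiproliferative activity, read by CellTiter-Glo and CCK-8 assay, with a stated time of 72 h; on this read-out lower numbers stand for stronger inhibition of growth and higher numbers for weaker inhibition of growth:
compound 1 `Cc1ccc(NC(=O)c2cccc(C(F)(F)F)c2)cc1N1Cc2cnc(O[C@H]3CCN(C(=O)OC(C)(C)C)C3)nc2N(C)C1=O`: 8380 nM
compound 2 `CNc1cc(Nc2ncc3c(n2)N(C)C(=O)N(c2cc(NC(=O)c4cccc(C(F)(F)F)c4)ccc2C)C3)ccc1C`: > 10000 nM
compound 3 `Cc1cccc(C(=O)Nc2ccc(C)c(N3Cc4cnc(Nc5ccc(C)c(N)c5)nc4N(C)C3=O)c2)c1`: > 10000 nM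

Compound 2 returns only a limit in this assay, > 10000 nM. Compound 3 likewise returns a limit, > 10000 nM. Across the set, (the limit of > 10000 nM in this assay, at which 2 of the 3 values shown sit). Among the compounds with values here, compound 1 is the only one with a number, 8380 nM. Compound 2 thus stands at the weak end of what has been measured, with no number to fix it.

Compound 4 `Cc1ccc(NC(=O)c2cccc(C(F)(F)F)c2)cc1N1Cc2cnc(OC3CCNCC3)nc2N(C)C1=O` differs from compound 2 in one place: (piperidin-4-yl)oxy in place of (4-methyl-3-(methylamino)phenyl)amino on an aromatic carbon. Within the data shown here, no measured pair differs in just this way, so the size of the step cannot be read from the data. Compound 1, which carries a ring ether with a protected nitrogen on the same aromatic carbon and gives 8380 nM, supports expecting a modest gain in this assay for compound 4, though the step may as well stay within scatter. The estimate for compound 4 is 6000 nM, within 1500 nM to 20000 nM. The expected step is an at least 1.6-fold lower number from compound 2 to compound 4 (0.22 log units; that floor lies within the scatter).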

Compound 4, concentration for 50% growth inhibition: > 10000 nM
Compound 4 was reported as a limit; the forecaster's own chance of this, stated with the estimate: 35%; at least 1.6-fold (0.22 log units) between middle value and limit.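

In this assay, compound 4 returns only a limit, > 10000 nM, so (piperidin-4-yl)oxy on this aromatic carbon gives no number either, and the step from compound 2 cannot be read. Placing piperidin-4-yl in place of 1-(tert-butoxycarbonyl)pyrrolidin-3-yl on the oxygen gives an at least 1.1-fold higher number from compound 1 to compound 4 (0.07 log units; that floor lies within the scatter), so this change shows no sign of a lower number. Compound 1 remains the only compound with a number, and the rest of the set sits at the limit: the limit of > 10000 nM in this assay, at which 3 of the 4 values shown sit.

From the compounds shown here alone, whether a methoxy group or a morpholine on this aromatic carbon would give a measurable number stays open. Also open, going by these compounds, is how far the value of compound 1 depends on the tert-butoxycarbonyl group and how far on the ring, as the two groups differ in both.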